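The source may hold more compounds than are shown below. What is called first, only, known or untested is meant among the compounds shown, and "the series" means these compounds.

For the measured compounds named here, compound 1 `CC(=O)NS(=O)(=O)c1ccc(N/C(S)=N\c2ccnc3cc(C(F)(F)F)ccc23)cc1` gives 37600 nM in a functional assay on AS49-RAW cells (Homo sapiens) for antiproliferative activity, read by sulforhodamine B assay, with a stated time of 48 h (on this read-out higher numbers stand for weaker inhibition and lower numbers for stronger inhibition), and of the two numbers known so far it stands together with compound 2 `Cc1cc(NS(=O)(=O)c2ccc(N/C(S)=N\c3ccnc4cc(C(F)(F)F)ccc34)cc2)on1`, which gives 60200 nM, the step of a 1.6-fold higher number from compound 1 to compound 2 (0.20 log units; within the scatter) staying within the scatter. Compound 3 `Cc1cc(C)nc(NS(=O)(=O)c2ccc(N/C(S)=N\c3ccnc4cc(C(F)(F)F)ccc34)cc2)n1` differs from compound 1 by 4,6-dimethylpyrimidin-2-yl in place of acetyl on a sulfonamide nitrogen. Going by the values given here, the only measured step that bears on this change, the one from compound 1 to compound 2 with a 1.6-fold higher number from compound 1 to compound 2 (0.20 log units; within the scatter), also swapped the acetyl on that sulfonamide nitrogen for a ring and stayed within the scatter, so no step beyond the scatter is expected in this assay. Compound 3 is therefore estimated at 45000 nM, between 18000 nM and 110000 nM, a step of a 1.2-fold higher number from compound 1 to compound 3 (0.08 log units; within the scatter).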

Compound 3, half-maximal inhibitory concentration: 43400 nM
Compound 3: the middle estimate sits 1.0-fold (0.02 log units) above what was measured; low and high end bracket the measured number.
By their numbers in this assay, from the lowest: compounds 1, 3 and 2 (each within the scatter of the next).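

On the sulfonamide nitrogen, 4,6-dimethylpyrimidin-2-yl in place of acetyl gives a small step (a 1.2-fold higher number from compound 1 to compound 3 (0.06 log units; within the scatter)), and in place of 3-methyl-1,2-oxazol-5-yl it also gives a small step (a 1.4-fold lower number from compound 2 to compound 3 (0.14 log units; within the scatter)). In this assay, this position has now carried acetyl and two different aromatic rings, and every step among them stays within the scatter. Nothing available explains this flat result. The compounds shown leave open whether a longer alkyl chain or a chain ending in a carboxylic acid on that nitrogen would move the number beyond the scatter. They also leave open whether a change elsewhere on the shared core would do so.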